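The compounds below may be only part of what the source reports. "The series", "measured", "known", "first", "only" and "open" are said of these compounds alone.

Working notes on the series. The shared core of compound 1 `COc1cc(C2=NN(C(C)=O)C(c3cccc(F)c3)O2)cc(OC)c1OC` carries a 3-fluorophenyl group on a saturated ring carbon; in a functional assay on PC-3 cells (Homo sapiens) for antiproliferative activity, read by MTT assay, tested at 5 uM (a higher number here means a stronger effect of the compound at the concentration tested, a lower number a weaker effect), compound 1 gives 43.5%. Compound 2 `COc1ccc(C2OC(c3cc(OC)c(OC)c(OC)c3)=NN2C(C)=O)c(OC)c1` replaces this with 2,4-dimethoxyphenyl and gives 92%, a step of a number 48.5 percentage points higher from compound 1 to compound 2 (beyond the scatter). Compound 3 `COc1cc(C(=O)N/N=C/c2ccccc2C(F)(F)F)cc(OC)c1OC` belongs to a different core and gives 52.9%. Among the measured compounds shown here, compound 3 thus stands well below compound 2, beyond the scatter, while its number and that of compound 1 lie within the usual scatter of each other; no single-point step connects compound 3 to either.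

Compound 4 `COc1cc(C(=O)N/N=C/c2ccccc2F)cc(OC)c1OC` differs from compound 3 by fluoro in place of trifluoromethyl on an aromatic carbon. For the measured compounds named here, the only measured step concerns a substituent on a saturated ring carbon of another core, so nothing measured speaks to an exchange of trifluoromethyl for fluoro on an aromatic carbon. Going by the values given here, with no bearing step, no change beyond the scatter is expected, so the estimated step is a number 2.9 percentage points lower from compound 3 to compound 4 (within the scatter). Compound 4 is therefore expected to give about 50%, in the range 30% to 70%.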

Compound 4, a percentage reported as inhibition, at one concentration (the size of the read-out at that concentration, not a potency): 81.8%
Compound 4: middle estimate off by 31.8 percentage points, on the low side; measured number outside the range, above it.
By their numbers in this assay, from the lowest: compounds 1 and 3 (each within the scatter of the next); then compound 4; then compound 2.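

The aromatic carbon ortho to a large group is not indifferent in this assay: fluoro in place of trifluoromethyl gives a number 28.9 percentage points higher from compound 3 to compound 4 (beyond the scatter) on this core. Among the compounds shown here, until now, the only measured step concerned a saturated ring carbon of another core, so this is the first sign that a change on the aromatic ring can also move the read-out beyond the scatter. In this pair, the group with 1 heavy atom goes with the higher number and the group with 4 heavy atoms with the lower, but nothing measured accounts for the step.

For the compounds shown here, with only two groups at this position, it remains open whether the read-out follows group size; chloro, methoxy or an amine on the same carbon would test this. Also open, as far as these compounds go, is whether the same exchange would give a step of similar size on the core of compound 1.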